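A few compounds are considered here, and "the series" means these few. Any claim that something is new, unique, unknown or untested is made for them only; others in the source may bear on it.

Compound 2 `CCN(CC)Cc1ccc2oc(=O)c(C(=O)Nc3ccccc3)cc2c1` holds the lowest of the two numbers in an assay on isolated protein for inhibition of coagulation factor XII (Homo sapiens), read by HPLC, with stated times of 10 min and 30 min, tested at 50 uM (a lower number here means less inhibition, a higher number more inhibition at the concentration tested (going by the name of the read-out)), where compound 2 gives 14%, though within the scatter of compound 1 `O=C(Nc1ccccc1)c1cc2cc(CN3CCCC3)ccc2oc1=O`, which gives 21%; the step of a number 7 percentage points lower from compound 1 to compound 2 (within the scatter) lies within the scatter. Compound 3 `O=C(Nc1ccccc1)c1cc2cc(CO)ccc2oc1=O` differs from compound 2 by hydroxy in place of diethylamino on a saturated chain carbon bound to an aromatic carbon. For the measured compounds named here, only the step from compound 1 to compound 2 bears on this change, and it stayed within the scatter, so no shift beyond the scatter is expected in this assay. The expected step of no change at the digits printed from compound 2 to compound 3 (within the scatter) is therefore small. Compound 3 is estimated to give 14%, between 0% and 35%.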

Compound 3, a percentage reported as inhibition, at one concentration (the size of the read-out at that concentration, not a potency) in the coagulation factor XII assay: 14%
Compound 3: middle estimate and measured number agree at the digits printed; low and high end bracket the measured number.
By their numbers in the coagulation factor XII assay, from the lowest: compounds 2, 3 and 1 (each within the scatter of the next).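

In the coagulation factor XII assay the step with hydroxy in place of diethylamino is no change at the digits printed from compound 2 to compound 3 (within the scatter) and the step with hydroxy in place of pyrrolidin-1-yl is a number 7 percentage points lower from compound 1 to compound 3 (within the scatter). On this saturated chain carbon bound to an aromatic carbon, a group without nitrogen thus reads the same as both amines, within the scatter. In a physicochemical assay for solubility, at pH 6.5 (on this read-out higher numbers stand for higher solubility and lower numbers for lower solubility), compound 2 gives 2900 ug/mL and compound 3 gives 52 ug/mL. The same change does separate the compounds in the physicochemical assay and costs solubility: the measured solubility of compound 2, 2900 ug/mL, and of compound 3, 52 ug/mL, a 56-fold lower number (1.75 log units; beyond the scatter). From the compounds shown here alone, whether a carboxylic acid or a longer chain on this carbon would move the number in the coagulation factor XII assay beyond the scatter stays open. These readings, each at one concentration, also give no potency.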